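A few compounds are considered here, and "the series" means these few. Any claim that something is new, unique, unknown or untested is made for them only; others in the source may bear on it.

In a functional assay on MCF7 cells (Homo sapiens) for cytotoxicity, read by MTT assay, with a stated time of 96 h (on this read-out higher numbers stand for weaker inhibition and lower numbers for stronger inhibition), compound 1, `COc1cc(C(=O)c2cn(-c3ccccc3)cc2-c2ccc(N)cc2)cc(OC)c1OC`, gives 9 nM, and compound 2, `COc1cc(C(=O)c2cn(-c3cccc(N)c3)cc2-c2ccc([N+](=O)[O-])cc2)cc(OC)c1OC`, gives 110 nM. Compound 2 therefore has the higher of the two numbers, which means weaker inhibition, and the gap between them lies beyond the scatter. These two compounds differ in more than one place, so their gap cannot be pinned on any single group.

Compound 3, `COc1cc(C(=O)c2cn(-c3cccc(N)c3)cc2-c2ccc(N)cc2)cc(OC)c1OC`, changes compound 2 in one place: amino in place of nitro on an aromatic carbon. This puts amino in place of nitro on an aromatic carbon, turning 4-nitrophenyl into 4-aminophenyl.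

For the measured compounds named here, no measured pair shows this change alone, so the best guide is compound 1, which carries the 4-aminophenyl group and gives 9 nM. On that basis, a clear move to a lower number in this assay, beyond the scatter, is expected, and the estimated step is a 5.5-fold lower number from compound 2 to compound 3 (0.74 log units; beyond the scatter). Compound 3 also keeps a second amino group that compound 1 lacks, and that difference has not been tested on its own, so the range is kept wide. The expected value for compound 3 is 20 nM, with an estimated range of 6 nM to 70 nM.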

Compound 3, half-maximal inhibitory concentration: 14 nM
Compound 3: middle estimate off by 1.4-fold (0.15 log units), on the high side; low and high end bracket the measured number.
By their numbers in this assay, from the lowest: compounds 1 and 3 (each within the scatter of the next); then compound 2.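

With this assay, the nitro to amino change on the 4-nitrophenyl group can now be read on its own, and it gives a 7.9-fold lower number from compound 2 to compound 3 (0.90 log units; beyond the scatter), so this place, para to a large group, clearly affects the read-out and the 4-aminophenyl form is the favoured one of the two. The amino group in place of hydrogen, which compound 3 carries and compound 1 lacks, gives a 1.6-fold higher number from compound 1 to compound 3 (0.19 log units; within the scatter), so this assay does not separate the two compounds, and in this pair that second amino group is tolerated with no change that can be told from the scatter. Nothing shown here explains why amino and nitro differ at the para place, and the step records only the outcome of the swap.

Going by these compounds, it remains open how other groups at that place, such as a hydroxyl, a methoxy or an acetamide, would compare with amino and nitro. On these data alone, it also remains open whether the second amino group would stay just as silent beside a nitro group, or whether a methyl amine or a hydroxyl in its place would shift the number.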